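A few compounds are considered here, and "the series" means these few. Any claim that something is new, unique, unknown or untested is made for them only; others in the source may bear on it.

Two compounds in this series share one core and differ only in the aryl group on an oxygen on a saturated carbon. Compound 1 `Cc1ccc(OCC(=O)Nc2ccc(OCC(=O)O)c(F)c2)cc1` carries a 4-methylphenyl there; in a functional assay on CHO cells for agonist activity at Free fatty acid receptor 1 (Homo sapiens), read by FLIPR, tested at 100 nM (a lower number here means a weaker effect, a higher number a stronger effect of the compound at the concentration tested), compound 1 gives 31.2%. Compound 2 `COc1cccc(OCC(=O)Nc2ccc(OCC(=O)O)c(F)c2)c1` carries a 3-methoxyphenyl instead, and in this assay compound 2 gives 31.7%. Within the data shown here, the one step so far, a number 0.5 percentage points higher from compound 1 to compound 2 (within the scatter), is within the scatter, so compound 2 and compound 1 stand side by side on this read-out and neither can be called the stronger.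

Compound 3 `COc1ccc(OCC(=O)Nc2ccc(OCC(=O)O)c(F)c2)cc1` is the next member. It has the same atoms as compound 2, joined differently: 4-methoxyphenyl in place of 3-methoxyphenyl on an oxygen on a saturated carbon. Among the measured compounds shown here, no measured step moves a methoxy group from one position of this ring to another, so the only guide is the step from compound 1 to compound 2, which stayed within the scatter when the whole aryl group was exchanged. On that basis no step beyond the scatter is expected for a number 0.7 percentage points lower from compound 2 to compound 3 (within the scatter), and compound 3 is estimated to give 31% in this assay, with a range from 15% to 48%.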

Compound 3, a percentage reported as activity, at one concentration (the size of the read-out at that concentration, not a potency) in the Free fatty acid receptor 1 assay: 5.73%
Beside the measured number, compound 3's estimate is 25.3 percentage points above it; the whole stated range lies above it.
By their numbers in the Free fatty acid receptor 1 assay, from the lowest: compound 3; then compounds 1 and 2 (each within the scatter of the next).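

The shift of the methoxy group is what counts here: in the Free fatty acid receptor 1 assay compound 3 gives 5.73%, and 4-methoxyphenyl in place of 3-methoxyphenyl on the oxygen gives a number 26 percentage points lower from compound 2 to compound 3 (beyond the scatter), even though the two groups have the same atoms and the same counts of rings, donors and acceptors. In the Free fatty acid receptor 1 assay the exchange of methyl for methoxy on an aromatic carbon gives a number 25.5 percentage points lower from compound 1 to compound 3 (beyond the scatter), so the aryl group at this position is not interchangeable, as the earlier pair alone might have suggested, and the read-out depends on both which group is present and where it sits on the ring. No evidence is at hand that accounts for this loss.

The compounds shown leave open whether the low number belongs to the 4-methoxyphenyl alone or extends to other groups here, such as 4-ethoxyphenyl, 4-chlorophenyl, 2-methoxyphenyl or an unsubstituted phenyl. They also leave open whether these differences in effect would hold at other concentrations, as the Free fatty acid receptor 1 assay reports a stronger or weaker effect at one concentration only. In a physicochemical assay for lipophilicity, using the shake flask method, at pH 7.4 (on this read-out lower numbers stand for lower lipophilicity and higher numbers for higher lipophilicity), compound 2 gives "not determined" (no result reported) and compound 3 gives "not determined" (no result reported), so no comparison can be read there.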